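Compound 4: the isopropyl change applied twice to compound 3

The source may hold more compounds than are shown below. What is called first, only, known or untested is meant among the compounds shown, and "the series" means these compounds.

As far as these compounds go, the study holds three measured compounds and one still open. In an ADME assay on HEL cells (Homo sapiens) for cytotoxicity, with a stated time of 3 days (a lower number here means that less compound is tolerated, a higher number that more compound is tolerated), compound 1 `Cc1cn([C@@H]2O[C@H](CO[Si](C)(C)C(C)(C)C)[C@@]3(OS(=O)(=O)C=C3NC(=O)NC(=O)c3ccccc3)[C@H]2O[Si](C)(C)C(C)(C)C)c(=O)n(C)c1=O` gives only a limit, > 200000 nM. Compound 2 `Cc1cn([C@@H]2O[C@H](CO[Si](C)(C)C(C)(C)C(C)C)[C@@]3(OS(=O)(=O)C=C3NC(=O)NC(=O)c3ccccc3)[C@H]2O[Si](C)(C)C(C)(C)C)c(=O)n(C)c1=O` likewise gives a limit in this assay, > 50000 nM. Compound 3 `Cc1cn([C@@H]2O[C@H](CO[Si](C)(C)C(C)(C)C)[C@@]3(OS(=O)(=O)C=C3NC(=O)NC(=O)c3ccccc3)[C@H]2O[Si](C)(C)C(C)(C)C(C)C)c(=O)n(C)c1=O` also gives a limit in this assay, >= 100000 nM. Because all three values sit at limits the limit of > 200000 nM in this assay, at which 1 of the 3 values shown sits, the limit of > 50000 nM in this assay, at which 1 of the 3 values shown sits (the limit of >= 100000 nM in this assay, at which 1 of the 3 values shown sits), neither step from compound 1 can be read: a step that the two limits leave unreadable from compound 1 to compound 2 and a step that the two limits leave unreadable from compound 1 to compound 3. Compound 3 therefore stands among three compounds that all reach a limit, with no number that would rank it against the others.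

Compound 4 `Cc1cn([C@@H]2O[C@H](CO[Si](C)(C)C(C)(C)C(C)C)[C@@]3(OS(=O)(=O)C=C3NC(=O)NC(=O)c3ccccc3)[C@H]2O[Si](C)(C)C(C)(C)C(C)C)c(=O)n(C)c1=O` is built from compound 3 by isopropyl in place of methyl on a saturated chain carbon bound to two saturated chain carbons and a silicon atom. Among the compounds with values here, the only measured steps that bear on this change are a step that the two limits leave unreadable from compound 1 to compound 2 and a step that the two limits leave unreadable from compound 1 to compound 3, both unreadable, and no other measured pair carries it. Nothing in the measured set therefore points to a step beyond the scatter in this assay in either direction, and the most likely outcome is a further limit. Compound 4 is accordingly expected to give 150000 nM in this assay, within 50000 nM to 400000 nM. The step this estimate means is a step that the limit leaves unreadable from compound 3 to compound 4, an expected change of no size beyond the scatter.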

Compound 4, half-maximal cytotoxic concentration: > 50000 nM
Compound 4 gave a limit, no number; the forecaster's own chance of this, stated with the estimate: 85%; the middle value lies beyond the limit too.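

In this assay compound 4 gives only a limit, > 50000 nM. Within the data shown here, compound 2 and compound 3 also give limits, and neither the step to compound 4 from compound 2 nor the one from compound 3 can be read. The compounds shown leave open whether isopropyl in place of methyl changes the tolerated concentration at all in this assay.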